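The compounds below may be only part of what the source reports. "The series", "measured", "known", "first", "only" and "open" are said of these compounds alone.

Measured to date in an assay on membranes from lung (Cavia porcellus) for binding affinity to cysteinyl leukotriene receptor (Homo sapiens); on this read-out higher numbers stand for weaker inhibition and lower numbers for stronger inhibition:
compound 1 `CC(CCC(=O)O)Cc1cccc(OCc2ccc3ccccc3n2)c1` — 140 nM
compound 2 `CC(Cc1cccc(OCc2ccc3ccccc3n2)c1)CC(C)C(=O)O` — 24 nM
compound 3 `CCCC(CCc1nnn[nH]1)Cc1cccc(OCc2ccc3ccccc3n2)c1` — 11 nM

Compound 3 stands lowest of the three numbers in this assay. Its nearest neighbour is compound 2, a higher number beyond the scatter; compound 1 lies furthest, higher by a margin well beyond the scatter.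

Compound 4 `CC(CCc1nnn[nH]1)Cc1cccc(OCc2ccc3ccccc3n2)c1` is the next point in the series. It differs from compound 3 by hydrogen in place of ethyl on a saturated chain carbon, three bonds along the chain from an aromatic carbon; cut one bond further out, the same change reads propyl to methyl.

Within the data shown here, only one measured step bears on a change of a saturated chain carbon: a 5.8-fold lower number from compound 1 to compound 2 (0.77 log units; beyond the scatter), in which methyl in place of hydrogen on the chain carbon bound to the carbonyl carbon gave the lower number. That step adds a chain carbon at a different place from the one altered here; compound 4 removes chain carbons instead. Taking the direction of that step as a guide, shortening the chain is expected to move the number upward by a modest amount, a 2.7-fold higher number from compound 3 to compound 4 (0.44 log units; beyond the scatter), rather than leave it within the scatter.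

The estimate for compound 4 in this assay is 30 nM, with a range from 10 nM to 90 nM.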

Compound 4, inhibition constant: 34 nM
For compound 4 the middle estimate is 1.1-fold (0.05 log units) below the measured one; the range from low to high includes it.
By their numbers in this assay, from the lowest: compound 3; then compounds 2 and 4 (each within the scatter of the next); then compound 1.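

In this assay, among these compounds, the step at the saturated chain carbon, three bonds along the chain from an aromatic carbon, is the first read at this position: hydrogen in place of ethyl gives a 3.1-fold higher number from compound 3 to compound 4 (0.49 log units; beyond the scatter), so the longer propyl chain of compound 3 goes with the lower number and the methyl of compound 4 with the higher one. The exchange of carboxy for 1H-tetrazol-5-yl, on a saturated chain carbon four bonds along the chain from an aromatic carbon, gives a 4.1-fold lower number from compound 1 to compound 4 (0.61 log units; beyond the scatter), while (1H-tetrazol-5-yl)methyl in place of 1-carboxyethyl gives a 1.4-fold higher number from compound 2 to compound 4 (0.15 log units; within the scatter), which lies within the scatter, so this second exchange separates the two compounds no more than repeat measurements would. Nothing at hand accounts for any of these steps.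

The compounds shown leave open whether a butyl chain or a longer one at the chain carbon carrying the propyl would continue the step seen here, or whether an amine at that carbon would be tolerated. They also leave open whether a carboxylic acid in place of the 1H-tetrazol-5-yl would keep the lower number when the propyl chain is present.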